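Ester in Place of Hydroxymethyl on a Shared Pyrazole Core

The source may hold more compounds than are shown below. What is called first, only, known or untested is meant among the compounds shown, and "the series" means these compounds.

Compound 3 `C/C=C/C(=O)Nc1ccc(Cn2nc(-c3ccc(Oc4ccccc4)cc3)cc2CO)cc1` and compound 1 `C/C=C/C(=O)Nc1ccc(Cn2nc(-c3ccc(Oc4ccccc4)cc3)cc2C(=O)OCC)cc1` share one core and differ in a single place: ethoxycarbonyl in place of hydroxymethyl on an aromatic carbon. In a functional assay on JeKo-1 cells (Homo sapiens) for inhibition, read by luminescence and CellTiter-Glo, with a stated time of 72 h (on this read-out higher numbers stand for weaker inhibition and lower numbers for stronger inhibition), compound 3 gives only a limit, > 60000 nM, and not a number. Compound 1 gives 52500 nM in this assay, so the change produced an at least 1.1-fold lower number from compound 3 to compound 1 (0.05 log units; that floor lies within the scatter). Compound 2 `C/C=C/C(=O)Nc1cccc(Cn2nc(-c3ccc(Oc4ccccc4)cc3)cc2CO)c1` holds the same atoms as compound 3 joined differently; the difference between the two cores is not broken down here. In this assay compound 2 gives 22600 nM. Compound 4 `C/C=C/C(=O)Nc1cccc(Cn2nc(-c3ccc(Oc4ccccc4)cc3)cc2C(=O)OCC)c1` is not yet measured and differs from compound 2 by the same change: ethoxycarbonyl in place of hydroxymethyl on an aromatic carbon. A small step is expected here, a 1.3-fold lower number from compound 2 to compound 4 (0.10 log units; within the scatter), which rests on an at least 1.1-fold lower number from compound 3 to compound 1 (0.05 log units; that floor lies within the scatter). Compound 4 is therefore expected near 18000 nM, with a likely range from 7000 nM to 45000 nM.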

Compound 4, half-maximal inhibitory concentration: 16700 nM
Beside the measured number, compound 4's estimate is 1.1-fold (0.03 log units) above it; the measured number falls inside the stated range.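

On the second core, ethoxycarbonyl in place of hydroxymethyl gives a 1.4-fold lower number from compound 2 to compound 4 (0.13 log units; within the scatter) in this assay, so here the swap leaves the number within the usual scatter. Set beside the first core, the change shows no firm sign of behaving differently, but a close match between the cores cannot be claimed: the same change on two cores in this assay, an at least 1.1-fold lower number (0.05 log units; that floor lies within the scatter) from compound 3 to compound 1 and a 1.4-fold lower number (0.13 log units; within the scatter) from compound 2 to compound 4; the limit leaves it open whether they differ. Among the two compounds bearing ethoxycarbonyl, 3-(((prop-1-en-1-yl)carbonyl)amino)phenyl in place of 4-(((prop-1-en-1-yl)carbonyl)amino)phenyl gives a 3.1-fold lower number from compound 1 to compound 4 (0.50 log units; beyond the scatter), a modest step that lies beyond the scatter and concerns a different change.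

As far as these compounds go, the true size of the step on the first core stays open, as compound 3 gives only a limit: the limit of > 60000 nM in this assay, at which 1 of the 4 values shown sits. From the compounds shown here alone, whether the result extends to a carboxylic acid or an amine at this place also stays open.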